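The source may hold more compounds than are shown below. What is called first, only, known or untested is meant among the compounds shown, and "the series" means these compounds.

Measured in a functional assay on MGC-803 cells (Homo sapiens) for inhibition, read by MTT assay, with a stated time of 48 h; on this read-out higher numbers stand for weaker inhibition and lower numbers for stronger inhibition:
- compound 1 `CCCCC(=O)N(Cc1ccc(OC)c(O)c1)c1cc(OC)c(OC)c(OC)c1`: 66 nM
- compound 2 `COc1ccc(CNc2cc(OC)c(OC)c(OC)c2)cc1Cl`: 46200 nM
- compound 3 `COC(=O)c1cc(CNc2cc(OC)c(OC)c(OC)c2)ccc1OC`: 49600 nM

Compound 1 has the lowest number of the three and is the most potent of them, while compound 2 and compound 3 both lie far above it. Compound 4 `CCC/C=C/C(=O)N(Cc1ccc(OC)c(O)c1)c1cc(OC)c(OC)c(OC)c1` has not yet been measured. It differs from compound 1 at one place: pent-1-en-1-yl in place of butyl on a carbonyl carbon. In short, pent-1-en-1-yl stands in place of butyl on a carbonyl carbon.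

Going by the values given here, only one measured step exists, a 1.1-fold higher number from compound 2 to compound 3 (0.03 log units; within the scatter). It lies within the scatter, but it concerns methoxycarbonyl in place of chloro on an aromatic carbon, not the chain on the carbonyl, so it bears on the new change only weakly. Among the compounds with values here, neither compound 2 nor compound 3 carries that chain, and no measured pair varies it. The size of this change is therefore not known from the data. With the rest of compound 1 left intact, no step beyond the scatter is expected in this assay, and any drift is expected towards a slightly higher number. The estimated step is a 1.5-fold higher number from compound 1 to compound 4 (0.18 log units; within the scatter). For compound 4 the expected value is 100 nM, with an estimated range from 30 nM to 350 nM.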

Compound 4, half-maximal inhibitory concentration: 70 nM
The estimate for compound 4 lay 1.4-fold (0.15 log units) above the measured number; the range from low to high includes it.
By their numbers in this assay, from the lowest: compounds 1 and 4 (each within the scatter of the next); then compounds 2 and 3 (each within the scatter of the next).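

In this assay, pent-1-en-1-yl in place of butyl on a carbonyl carbon gives a 1.1-fold higher number from compound 1 to compound 4 (0.03 log units; within the scatter), so the two compounds cannot be told apart on this read-out. Going by these compounds alone, this is the first measured pair that varies the chain at this place, and it shows that the number stays within the scatter when butyl, with 4 carbon, gives way to pent-1-en-1-yl, with 5 carbon and a double bond outside aromatic rings. No measurement at hand explains why these two chains read alike in this assay.

This single step carries the extra carbon and the double bond together, and the compounds shown do not separate the two, which pentyl on the same carbonyl carbon would begin to do. They also leave open how far the latitude at this place extends, since a much longer chain such as decyl, a phenyl ring, or a chain ending in an amine or a carboxylic acid could give a number either close to or far from those of this pair.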